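Cytotoxicity notes on the shared-core amide series

The source may report more compounds than this note shows. Statements on the series, on what has been measured and on what is new or still open speak of the compounds shown alone.

Compound 1, `CC(C)(C)OC(=O)Nc1ncc(C(Oc2ccc3cc(Br)ccc3c2)c2ccc(Cl)cc2)s1`, gives only a limit in an ADME assay on HepG2 2.2.15 cells (Homo sapiens) for cytotoxicity; on this read-out lower numbers stand for higher toxicity in this test and higher numbers for lower toxicity in this test: > 50000 nM.
Compound 2, `CCCCC(CC)CNc1ncc(C(Oc2ccc3cc(Br)ccc3c2)c2ccc(Cl)cc2)s1`, gives "not toxic" (no number reported) in this assay.
Compound 3, `O=C(Nc1ncc(C(Oc2ccc3cc(Br)ccc3c2)c2ccc(Cl)cc2)s1)C1CC1`, gives "not toxic" (no number reported) in this assay.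

Compound 3 therefore stands without a single number in this assay; of the two other entries, one is a limit and the other also carries no number. The one limit sits at the limit of > 50000 nM in this assay, at which 1 of the 3 values shown sits.

Compound 4, `O=C(Nc1ncc(C(Oc2ccc3cc(Br)ccc3c2)c2ccc(Cl)cc2)s1)C1CCOCC1`, differs from compound 3 in one place: oxan-4-yl in place of cyclopropyl on a carbonyl carbon. Among the measured compounds shown here, no measured step covers this change. In this assay no shift beyond the scatter is expected from compound 3 to compound 4, in either direction, so a reading at or past the limit is the expectation.

For compound 4 the estimated half-maximal cytotoxic concentration is 60000 nM, within a range from 20000 nM to 200000 nM.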

Compound 4, half-maximal cytotoxic concentration: "not toxic" (no number reported)
For compound 4 the study gives words and no number; there is nothing to compare the estimate with.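

Compound 3 and compound 4 both read "not toxic" without a number in this assay, so no step can be read between them. The compounds shown leave open at what concentration toxicity would appear, the only figure being the limit of compound 1: the limit of > 50000 nM in this assay, at which 1 of the 4 values shown sits.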